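Ethyl in Place of Hydrogen on the Shared Core

A few compounds are considered here, and "the series" means these few. Any claim that something is new, unique, unknown or untested is made for them only; others in the source may bear on it.

Measured compounds:
Compound 1, `Cc1ccccc1-c1n[nH]c(-c2ccccc2)n1`, gives 10 mg/kg in a functional assay on the whole organism (Cricetulus griseus) with Cricetinae gen. sp. as the target; on this read-out lower numbers stand for an effect already at smaller amounts and higher numbers for an effect only at larger amounts of compound.
Compound 2, `c1ccc(-c2n[nH]c(-c3ccccc3)n2)cc1`, gives 10 mg/kg in this assay.

Compound 2 stands level with compound 1 on the numbers shown: the step of no change at the digits printed from compound 1 to compound 2 (within the scatter) was no change within the scatter, and compound 1 is its only measured neighbour. The compound now to be measured is compound 3, `CCc1ccccc1-c1n[nH]c(-c2ccccc2)n1`. It differs from compound 2 by ethyl in place of hydrogen on an aromatic carbon.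

Among the compounds with values here, only one measured step bears on this change, no change at the digits printed from compound 1 to compound 2 (within the scatter), which is the reverse direction of a small alkyl group entering at the same kind of place and was flat. Within the data shown here, with ethyl being the entering group here rather than methyl, no measured step speaks directly for it, but the one that comes closest showed nothing beyond the scatter. The account therefore expects the step of no change at the digits printed from compound 2 to compound 3 (within the scatter) to stay within the usual scatter, in no particular direction. Compound 3 is accordingly estimated at 10 mg/kg, with a range from 5 mg/kg to 20 mg/kg in this assay.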

Compound 3, dose for half-maximal effect: 5 mg/kg
The estimate for compound 3 lay 2.0-fold (0.30 log units) above the measured number, and the stated range covers the measured number.
By their numbers in this assay, from the lowest: compounds 3, 1 and 2 (each within the scatter of the next).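

In this assay the entry of ethyl on an aromatic carbon ortho to a large group gives a 2.0-fold lower number from compound 2 to compound 3 (0.30 log units; within the scatter) and so stays inside the usual scatter, which shows that this place accepts a group of 2 carbon as well as the methyl of compound 1 without a step that can be told from repeat measurement. Read from the methyl side, the change of methyl in place of hydrogen on a saturated chain carbon bound to an aromatic carbon gives a 2.0-fold lower number from compound 1 to compound 3 (0.30 log units; within the scatter) and is likewise within the scatter, so compounds 1, 2 and 3 cannot be ranked on this read-out, and hydrogen, methyl and ethyl are not told apart here. Nothing besides these dose figures bears on the result, and the flat steps therefore stand without any explanation.

The three compounds leave open whether a longer chain such as propyl, a branched group such as isopropyl, or a group of another kind such as an amine or a carboxylic acid at this same place would bring a step beyond the scatter. They also leave open what a group on the other six-membered aromatic ring would do, since every change shown lies on one ring only.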